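Dropping the Bromo Group on a Fatty Acid Receptor Agonist

The compounds below may be only part of what the source reports. "The series", "measured", "known", "first", "only" and "open" are said of these compounds alone.

Measured compounds:
Compound 1 `O=C(O)C1CC1c1ccc(NCc2cccc(Oc3ccccc3)c2)cc1`: 74%
Compound 2 `O=C(O)CCc1ccc(NCc2cccc(Br)c2)cc1`: 120%

Both compounds were tested in a functional assay on CHO cells for agonist activity at Free fatty acid receptor 1 (Homo sapiens), read by reporter gene assay; on this read-out higher numbers stand for larger maximal responses and lower numbers for smaller maximal responses. Compound 2 gives 120%, the highest of the two numbers, while compound 1 gives 74%, a lower value, and the two compounds differ in more than one place, so only what the two values show can be said. Compound 3 `O=C(O)CCc1ccc(NCc2ccccc2)cc1` has not yet been measured. Compared with compound 2, the change is hydrogen in place of bromo on an aromatic carbon. Among the compounds with values here, with no step between measured compounds available, the expectation rests on the structural change alone. A moderate decrease in maximal response beyond the scatter is expected in this assay, though a result within the scatter of compound 2 cannot be excluded. The step of a number 25 percentage points lower from compound 2 to compound 3 (beyond the scatter) is what this estimate means. Compound 3 is expected to reach 95%, with a range from 65% to 120%.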

Compound 3, largest response reached (reported as percent of maximum), in percent of the reference or control that the assay uses: 144%
Beside the measured number, compound 3's estimate is 49 percentage points below it, outside the stated range (above it).
By their numbers in this assay, from the lowest: compound 1; then compound 2; then compound 3.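

In this assay, the bromo group on this aromatic carbon is not needed for a large maximal response: with hydrogen in its place, the read-out shows a number 24 percentage points higher from compound 2 to compound 3 (beyond the scatter). This is the first comparison among the compounds shown that differ in one place, so a change in maximal response can now be tied to this single position. Removing the one heavy atom here raises the number rather than lowering it, but nothing at hand accounts for this rise.

The compounds shown leave open how other groups on this carbon, such as fluoro, methoxy or an amine, would compare with the hydrogen of compound 3. They also leave open whether hydrogen in place of a group at this position would give a similar rise on the core of compound 1.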